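The source may report more compounds than this note shows. Statements on the series, on what has been measured and on what is new or still open speak of the compounds shown alone.

Working notes on the series.

Compound 1 `COc1cc2c(Oc3ccc(NC(=O)c4cc(-c5ccccc5)ccn4)cc3F)ccnc2cc1OCCCN1CCN(C)CC1` carries a 4-methylpiperazin-1-yl end on the propyl chain and an unsubstituted phenyl on the pyridine amide. In a functional assay on U-87MG ATCC cells (Homo sapiens) for cytotoxicity, read by MTT assay, with a stated time of 72 h (on this read-out higher numbers stand for weaker inhibition and lower numbers for stronger inhibition), compound 1 gives 1010 nM. Compound 2 `COc1cc2c(Oc3ccc(NC(=O)c4cc(-c5ccccc5C)ccn4)cc3F)ccnc2cc1OCCCN1CCN(C)CC1` differs from it only by methyl in place of hydrogen on an aromatic carbon; in this assay compound 2 gives 2030 nM, so the step is a 2.0-fold higher number from compound 1 to compound 2 (0.30 log units; within the scatter). Compound 3 `COc1cc2c(Oc3ccc(NC(=O)c4cc(-c5ccccc5)ccn4)cc3F)ccnc2cc1OCCCN1CCCC1` keeps the phenyl of compound 1 but changes the chain end, (pyrrolidin-1-yl in place of 4-methylpiperazin-1-yl on a saturated chain carbon, three bonds along the chain from an oxygen on an aromatic ring); in this assay compound 3 gives 1010 nM, and the step is no change at the digits printed from compound 1 to compound 3 (within the scatter).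

Compound 4 `COc1cc2c(Oc3ccc(NC(=O)c4cc(-c5ccc(C)cc5)ccn4)cc3F)ccnc2cc1OCCCN1CCCC1` has not yet been measured. It stands to compound 3 as compound 2 stands to compound 1: the counted difference is methyl in place of hydrogen on an aromatic carbon. The two changes are the same kind of change, not the same: in compound 2 the methyl sits ortho to a large group, in compound 4 it sits para to a large group. The cores of the two pairs differ by pyrrolidin-1-yl in place of 4-methylpiperazin-1-yl on a saturated chain carbon, three bonds along the chain from an oxygen on an aromatic ring, a change that left the number unmoved between compound 1 and compound 3.

For the measured compounds named here, the only measured methyl step, a 2.0-fold higher number from compound 1 to compound 2 (0.30 log units; within the scatter), lay within the scatter, and there is no measured para-methyl pair to draw on. The step from compound 3 to compound 4 is therefore expected to be small, about a 1.5-fold higher number from compound 3 to compound 4 (0.17 log units; within the scatter), resting on the step of a 2.0-fold higher number from compound 1 to compound 2 (0.30 log units; within the scatter) and on the unchanged value of compound 3 1010 nM. Compound 4 is estimated at 1500 nM in this assay, with a range from 600 nM to 4000 nM.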

Compound 4, half-maximal inhibitory concentration: 560 nM
The estimate for compound 4 lay 2.7-fold (0.43 log units) above the measured number; the measured number lies below the stated range.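

In this assay, methyl in place of hydrogen, para to a large group, gives a 1.8-fold lower number from compound 3 to compound 4 (0.26 log units; within the scatter), a step that on its own does not stand out from repeat measurements. Set beside a 2.0-fold higher number from compound 1 to compound 2 (0.30 log units; within the scatter), it shows that one number for this change does not carry from the core of compound 1 to the core of compound 3, even though neither step alone is beyond the scatter: the same change on two cores in this assay, a 2.0-fold higher number (0.30 log units; within the scatter) from compound 1 to compound 2 and a 1.8-fold lower number (0.26 log units; within the scatter) from compound 3 to compound 4, 3.6-fold (0.56 log units) apart, beyond the scatter of two such steps What this does not show is the source of the disagreement, since the two pairs differ both in the chain end, pyrrolidin-1-yl against 4-methylpiperazin-1-yl, and in where the methyl sits on the phenyl, so the place of the methyl and the core cannot be told apart here.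

Left open is whether a 4-methylphenyl on the 4-methylpiperazin-1-yl chain end would follow compound 4, and whether the methylated phenyl of compound 2 on the pyrrolidin-1-yl chain end would follow compound 2, either of which would separate the two differences. Also open, from the compounds shown here alone, is how a methoxy or a chlorine in the place of this methyl would behave, or a morpholin-4-yl at the end of the propyl chain.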